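This account rests on a few compounds, and the source may have more. Where it says the series, first, only, none or still open, it means among the compounds named here.

Measured so far:
Compound 1 `C=CCOc1cc(OC)c(C(=O)/C=C/C=C/c2ccccc2)c(OCC=C)c1` gives "not determined" (no result reported)
Compound 2 `C=CCOc1cc(OC)c(C(=O)/C=C/c2ccc(F)cc2)c(OCC=C)c1` gives 13600 nM
Compound 3 `C=CCOc1cc(OC)c(C(=O)/C=C/c2ccccc2)c(OCC=C)c1` gives 17100 nM

These entries all come from an ADME assay on Vero cells (Chlorocebus sabaeus) for cytotoxicity, read by MTT assay (on this read-out lower numbers stand for stronger inhibition and higher numbers for weaker inhibition), and can be compared directly. Compound 1 has no place on this scale: compound 1 shows "not determined" (no result reported) in this test, so it offers no starting number. Compound 4 `C=CCOc1cc(OC)c(C(=O)/C=C/c2ccc(C(F)(F)F)cc2)c(OCC=C)c1` is still unmeasured. The change from compound 1 to compound 4 is 4-(trifluoromethyl)phenyl in place of 2-phenylethenyl on a double-bonded chain carbon bound to a double-bonded chain carbon and consists of 4-(trifluoromethyl)phenyl in place of 2-phenylethenyl on a double-bonded chain carbon bound to a double-bonded chain carbon.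

With no number for compound 1, no size or direction can be expected for this step itself. Guidance has to come from the two measured neighbours, which carry a fluoro or a hydrogen on their aromatic ring where compound 4 has its trifluoromethyl group. For the measured compounds named here, the one measured step is a 1.3-fold higher number from compound 2 to compound 3 (0.10 log units; within the scatter) and it stays within the scatter. Going by the values given here, that single step is thin evidence, and no measured compound carries trifluoromethyl. In this assay a value close to those two neighbours is therefore expected, with no difference beyond the scatter and no favoured direction. Compound 4 is expected at about 14000 nM with an estimated range from 6000 nM to 32000 nM in this test.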

Compound 4, half-maximal inhibitory concentration: 7200 nM
Compound 4: middle estimate off by 1.9-fold (0.29 log units), on the high side; the measured number falls inside the stated range.
By their numbers in this assay, from the lowest: compounds 4, 2 and 3 (each within the scatter of the next, the first and the last beyond it).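

In this assay, the aromatic carbon that carries the substituent now proves able to shift the number: trifluoromethyl in place of hydrogen gives a 2.4-fold lower number from compound 3 to compound 4 (0.38 log units; beyond the scatter), a modest step but the first one here to pass beyond the usual scatter, whereas the earlier exchange of fluoro for hydrogen gave only a 1.3-fold higher number from compound 2 to compound 3 (0.10 log units; within the scatter) and stayed within it. The size of the change is limited, though, since trifluoromethyl in place of fluoro gives a 1.9-fold lower number from compound 2 to compound 4 (0.28 log units; within the scatter), which lies within the scatter, so these two groups cannot be told apart in this test and only the compound with hydrogen stands clearly apart from compound 4. Nothing shown here explains why the trifluoromethyl compound separates from the hydrogen compound.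

Going by these compounds, compound 1 has no number to start from, so its step to compound 4 cannot be read, and the effect of exchanging the 2-phenylethenyl group stays unknown. On these data alone, it also remains open whether a quite different group on the same aromatic carbon, such as an amine or a carboxylic acid, would move the number further, and in which direction.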